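Cytotoxicity of a thiocarbamate series: one change examined

The source may report more compounds than this note shows. Statements on the series, on what has been measured and on what is new or still open speak of the compounds shown alone.

Measured compounds:
compound 1, `CCCCCOc1ccc(C(=O)N(C(=S)OCCN2C(=O)c3ccccc3C2=O)c2ccc(F)cc2)cc1`: > 100000 nM
compound 2, `O=C1c2ccccc2C(=O)N1CCOC(=S)N(C(=O)c1ccc(C(F)(F)F)cc1)c1ccc(Cl)cc1`: 10000 nM

The account concerns two measured compounds and one that awaits measurement, all of them studied in an ADME assay on MT4 cells (Homo sapiens) for cytotoxicity, read by MTT assay; on this read-out higher numbers stand for lower toxicity in this test and lower numbers for higher toxicity in this test. Compound 1 reaches only a limit of the assay, as its value > 100000 nM is a limit and not a number; this is set down as the limit of > 100000 nM in this assay, at which 1 of the 2 values shown sits. Compound 2 gives 10000 nM in this assay, and it is the only number shown.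

The step of interest leads from compound 2 to compound 3, whose structure is `O=C1c2ccccc2C(=O)N1CCOC(=S)N(C(=O)c1cc(Cl)cc(Cl)c1)c1ccc(Cl)cc1`. The change between them is 3,5-dichlorophenyl in place of 4-(trifluoromethyl)phenyl on a carbonyl carbon. For the measured compounds named here, no measured pair with a single difference is available, so the size of this step in this assay cannot be read from the data. The expectation is that the step from compound 2 to compound 3 is small, of the order of the scatter, as a 1.5-fold higher number from compound 2 to compound 3 (0.18 log units; within the scatter). Compound 3 is thus estimated at 15000 nM, with a range from 4000 nM to 60000 nM.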

Compound 3, half-maximal cytotoxic concentration: 32000 nM
Compound 3: middle estimate off by 2.1-fold (0.33 log units), on the low side; the measured number falls inside the stated range.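

In this assay, this step gives the first readable size for a change at this place, on a carbonyl carbon whose other neighbours are an amide-type nitrogen: 3,5-dichlorophenyl in place of 4-(trifluoromethyl)phenyl gives a 3.2-fold higher number from compound 2 to compound 3 (0.51 log units; beyond the scatter). The position therefore responds in this test, even though the group that leaves and the group that enters each hold one six-membered aromatic ring of carbon only and neither has a hydrogen-bond donor or acceptor. No measurement shown bears on why the number moves at this position.

Steps involving compound 1 cannot be read, as it differs from the other two compounds in more than one place, and it remains open whether the shift follows from the loss of trifluoromethyl or from the arrival of the two chlorines. The compounds shown also leave open how a phenyl carrying a single chlorine, a carboxylic acid or an amine would fare on the same carbonyl carbon.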